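Swapping a nitro group for three fluorines

This account rests on a few compounds, and the source may have more. Where it says the series, first, only, none or still open, it means among the compounds named here.

Measured compounds:
compound 1, `CC(C)[C@H](NC(=O)COc1cccc2ccccc12)C(=O)N[C@@H](CC(=O)O)C(=O)COc1ccccc1[N+](=O)[O-]`: 27700 nM
compound 2, `CC(C)[C@H](NC(=O)COc1cccc2ccccc12)C(=O)N[C@@H](CC(=O)O)C(=O)COc1ccc([N+](=O)[O-])cc1`: 22800 nM

Both compounds were tested in a functional assay with Homo sapiens as the target; a higher number here means a weaker inhibitor, a lower number a stronger inhibitor. Among the two numbers, compound 2 has the lower one, but the difference between compound 1 and compound 2 is a 1.2-fold lower number from compound 1 to compound 2 (0.08 log units; within the scatter), so the two compounds cannot be told apart on this evidence.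

Compound 3, `CC(C)[C@H](NC(=O)COc1cccc2ccccc12)C(=O)N[C@@H](CC(=O)O)C(=O)COc1ccc(F)c(F)c1F`, has not yet been measured in this assay. It differs from compound 2 in one place: 2,3,4-trifluorophenyl in place of 4-nitrophenyl on an oxygen on a saturated carbon. Among the compounds with values here, no measured step speaks to this kind of change. Within the data shown here, the only step known, a 1.2-fold lower number from compound 1 to compound 2 (0.08 log units; within the scatter), moved the nitro group around the ring and left the number essentially where it was; it says nothing about removing the nitro group altogether and bringing in fluorines. With nothing to point in either direction, the expectation for compound 3 is a number near that of compound 2, with a wide range around it to allow for the untested change, which amounts to an expected 1.0-fold lower number from compound 2 to compound 3 (0.02 log units; within the scatter). The estimate for compound 3 is therefore 22000 nM, expected to lie between 7000 nM and 70000 nM.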

Compound 3, half-maximal inhibitory concentration: 20600 nM
Estimate against measurement, compound 3: 1.1-fold (0.03 log units) above; measured number inside the range.
By their numbers in this assay, from the lowest: compounds 3, 2 and 1 (each within the scatter of the next).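

In this assay, the step from the nitro-bearing ring to the fluorinated one is small in both comparisons (a 1.1-fold lower number from compound 2 to compound 3 (0.04 log units; within the scatter)) and (a 1.3-fold lower number from compound 1 to compound 3 (0.13 log units; within the scatter)), so the three compounds cannot be told apart. Within the data shown here, the earlier pair showed only that the nitro group could sit in a different place on the ring without a measurable difference, whereas these steps show that, within this set, the 4-nitrophenyl or 2-nitrophenyl group on this oxygen can be exchanged for 2,3,4-trifluorophenyl, a group with no nitrogen or oxygen atoms, again without a measurable difference. No supporting measurement bears on this result.

From the compounds shown here alone, all three compounds still carry a substituted phenyl ring at this position, so it remains open whether an unsubstituted phenyl ring, a ring with a single chlorine or methoxy group, or a simple amine in place of the ring would give a number distinguishable from these. Going by these compounds, it is equally open whether any change at this position can move the number beyond the scatter, or whether a change elsewhere on the shared core would be needed.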